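A few compounds are considered here, and "the series" means these few. Any claim that something is new, unique, unknown or untested is made for them only; others in the source may bear on it.

Measured so far in a physicochemical assay for solubility; on this read-out lower numbers stand for lower solubility and higher numbers for higher solubility

- compound 1 `CC(C)(C)OC(=O)N1CCC[C@@H]1C(=O)N1CCC(NS(=O)(=O)c2cc(S(=O)(=O)c3ccccc3)ccc2C(F)(F)F)CC1` gives 25000 nM
- compound 2 `CN(C)c1ccc(C(=O)N2CCC[C@H]2C(=O)N2CCC(NS(=O)(=O)c3cc(S(=O)(=O)c4ccccc4)ccc3C(F)(F)F)CC2)cc1` gives 100000 nM
- compound 3 `O=C([C@@H]1CCCN1C(=O)Nc1ccccc1)N1CCC(NS(=O)(=O)c2cc(S(=O)(=O)c3ccccc3)ccc2C(F)(F)F)CC1` gives 25000 nM

Compound 3 stands at 25000 nM, level with compound 1, and together they hold the lowest number of the three. The next compound to be tested is compound 4 `CN1CCC[C@H]1C(=O)N1CCC(NS(=O)(=O)c2cc(S(=O)(=O)c3ccccc3)ccc2C(F)(F)F)CC1`, which has methyl in place of phenylcarbamoyl on an amine nitrogen in a ring. Among the measured compounds shown here, only one measured step bears on this change, since it alters the group on that same nitrogen: a 4.0-fold lower number from compound 2 to compound 3 (0.60 log units; beyond the scatter). It is modest but beyond the scatter. Compound 1 goes against any simple trend, as it matches compound 3 while carrying a different group there. For the measured compounds named here, no measured compound has methyl on this nitrogen, so the expectation is loose. A modest rise in this assay is expected, towards compound 2 at 100000 nM. The estimated step is a 3.2-fold higher number from compound 3 to compound 4 (0.51 log units; beyond the scatter). Compound 4 is expected at 80000 nM, within an estimated range of 25000 nM to 250000 nM.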

Compound 4, solubility: 100000 nM
The estimate for compound 4 lay 1.3-fold (0.10 log units) below the measured number; the range from low to high includes it.
By their numbers in this assay, from the lowest: compounds 1 and 3 (each within the scatter of the next); then compounds 2 and 4 (each within the scatter of the next).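

In this assay, the group on this ring nitrogen now splits the compounds into two levels: methyl in place of phenylcarbamoyl raises the number (a 4.0-fold higher number from compound 3 to compound 4 (0.60 log units; beyond the scatter)), and methyl in place of the tert-butoxycarbonyl group of compound 1 does much the same (a 4.0-fold higher number from compound 1 to compound 4 (0.60 log units; beyond the scatter)). Size alone does not sort these compounds, since the large (4-(dimethylamino)phenyl)carbonyl group of compound 2 goes against any trend towards higher numbers with smaller groups, and methyl matches it (no change at the digits printed from compound 2 to compound 4 (within the scatter)). No measurement here explains why these groups fall on the two levels.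

Still open, as far as these compounds go, is how this nitrogen would read with only a hydrogen on it, or with an ethyl or acetyl group. A carboxylic acid or a primary amine carried on a short chain at this nitrogen also remains untested among the compounds shown.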